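Trifluoromethoxy for methoxy on the piperazine aryl

This account rests on a few compounds, and the source may have more. Where it says the series, first, only, none or still open, it means among the compounds named here.

Measured so far:
compound 1 `Nc1scc(CN2CCN(c3cccc(Cl)c3Cl)CC2)c1C(=O)c1ccc(Cl)cc1` gives -57%
compound 2 `Nc1scc(CN2CCN(c3ccc(F)cc3Cl)CC2)c1C(=O)c1ccc(Cl)cc1` gives -39%
compound 3 `COc1ccc(N2CCN(Cc3csc(N)c3C(=O)c3ccc(Cl)cc3)CC2)cc1` gives -15%

All three were read in a functional assay on CHO cells with adenosine receptor A1 (Homo sapiens) as the target, read by cAMP accumulation and immunoassay, with a stated time of 6 min, tested at 1 uM; on this read-out higher numbers stand for a weaker effect at the one concentration tested and lower numbers for a stronger effect. Compound 3 stands highest of the three: the steps of a number 42 percentage points higher from compound 1 to compound 3 (beyond the scatter) and a number 24 percentage points higher from compound 2 to compound 3 (beyond the scatter) both lie beyond the scatter, as does a number 18 percentage points higher from compound 1 to compound 2 (beyond the scatter). All measured steps change the aryl on the amine nitrogen in the ring as a whole.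

Compound 4 `Nc1scc(CN2CCN(c3ccc(OC(F)(F)F)cc3)CC2)c1C(=O)c1ccc(Cl)cc1` differs from compound 3 by trifluoromethyl in place of methyl on an oxygen on an aromatic ring. Going by the values given here, no measured step isolates a change on the oxygen on the aromatic ring, so the three aryl swaps give no direct guide, only the general observation that the aryl matters.

Compound 4 is therefore expected near compound 3, with a number 5 percentage points lower from compound 3 to compound 4 (within the scatter) within the scatter. The estimate for compound 4 is -20%, with a range from -45% to 5%.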

Compound 4, a percentage reported as activity, at one concentration (the size of the read-out at that concentration, not a potency): -51%
Beside the measured number, compound 4's estimate is 31 percentage points above it, and the stated range ends above it.
By their numbers in this assay, from the lowest: compounds 1 and 4 (each within the scatter of the next); then compound 2; then compound 3.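

In this assay the group on the oxygen on the aromatic ring counts on its own, with a number 36 percentage points lower from compound 3 to compound 4 (beyond the scatter) for trifluoromethyl in place of methyl and nothing else changed. Chlorine on the piperazine aryl is not needed for a low number, with a number 12 percentage points lower from compound 2 to compound 4 (beyond the scatter) and a number 6 percentage points higher from compound 1 to compound 4 (within the scatter) for the chlorine-free 4-(trifluoromethoxy)phenyl. No data at hand explain the size of the step.

Open, on these data alone, is how an ethoxy or a dimethylamino group in place of trifluoromethoxy on that aryl would read. Also open, as far as these compounds go, is whether the same exchange on the oxygen holds with other groups on the shared core.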